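This account rests on a few compounds, and the source may have more. Where it says the series, first, only, none or still open, it means among the compounds named here.

Measured compounds:
compound 1, `Nc1ccccc1NC(=O)/C=C/c1ccc(Cn2cnc3c(Nc4cccc(Cl)c4)nc(Cl)nc32)cc1`: 7.11%
compound 2, `Nc1ccccc1NC(=O)/C=C/c1ccc(Cn2cnc3c(NC4CCCCC4)nc(Cl)nc32)cc1`: 8.09%

In a functional assay on NCI-H460 cells (Homo sapiens) for antiproliferative activity, read by CCK-8 assay, with a stated time of 72 h, tested at 2 uM (a lower number here means a weaker effect, a higher number a stronger effect of the compound at the concentration tested), compound 2 has the highest of the two numbers shown, but compound 1 sits within the scatter of it, so the two cannot be told apart. Compound 3, `Nc1ccccc1NC(=O)/C=C/c1ccc(Cn2cnc3c(Nc4ccccc4)nc(Cl)nc32)cc1`, differs from compound 2 by phenyl in place of cyclohexyl on a nitrogen on an aromatic ring. Within the data shown here, the only measured step bearing on this change is a number 1 percentage points higher from compound 1 to compound 2 (within the scatter), in which a ring of the aromatic kind gave way to the cyclohexyl with no effect beyond the scatter. Going back to an aromatic ring, now phenyl, is expected to give a number 0.6 percentage points lower from compound 2 to compound 3 (within the scatter). Compound 3 is estimated at 7.5%, in the range 0% to 16%.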

Compound 3, a percentage reported as inhibition, at one concentration (the size of the read-out at that concentration, not a potency): 2.05%
For compound 3 the middle estimate is 5.5 percentage points above the measured one, and the stated range covers the measured number.
By their numbers in this assay, from the lowest: compounds 3, 1 and 2 (each within the scatter of the next).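

In this assay the swap of cyclohexyl for phenyl gives a number 6 percentage points lower from compound 2 to compound 3 (within the scatter), and hydrogen in place of chloro on an aromatic carbon gives a number 5.1 percentage points lower from compound 1 to compound 3 (within the scatter), so neither change separates the compounds. At this nitrogen, an aromatic and a non-aromatic six-membered ring cannot be told apart at the concentration tested, with or without the chloro. No evidence bears on these numbers. Going by these compounds, it remains open whether any group on this nitrogen would move the number beyond the scatter. A longer chain in place of the ring, or an amine or a carboxylic acid on the phenyl, would test this.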